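From a methyl amide to a 2-hydroxyethyl amide

This account rests on a few compounds, and the source may have more. Where it says the series, first, only, none or still open, it means among the compounds named here.

Compound 1 `COc1ccc(C(N)=O)cc1/C=C/c1ccc(Cl)cc1` gives 7100 nM (a number)
Compound 2 `COc1ccc(C(N)=O)cc1/C=C/c1ccc(Cl)cc1F` gives > 10000 nM (a limit of the assay, not a number)
Compound 3 `CNC(=O)c1ccc(OC)c(/C=C/c2ccc(Cl)cc2)c1` gives 16000 nM (a number)

In an ADME assay on HCT-116 cells (Homo sapiens) for antiproliferative activity (on this read-out higher numbers stand for weaker inhibition and lower numbers for stronger inhibition), compound 3 holds the higher of the two exact numbers (16000 nM), and its nearest neighbour is compound 1 (7100 nM). Placing a methyl on the amide-type nitrogen gave a modest change (a 2.3-fold higher number from compound 1 to compound 3 (0.35 log units; beyond the scatter)). The fluoro swap on an aromatic carbon (an at least 1.4-fold higher number from compound 1 to compound 2 (0.14 log units; that floor lies within the scatter)) does not touch the amide and says little here.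

Compound 4 `COc1ccc(C(=O)NCCO)cc1/C=C/c1ccc(Cl)cc1` differs from compound 3 by one change (hydroxymethyl in place of hydrogen on a saturated chain carbon bound to an amide-type nitrogen), which turns methyl into 2-hydroxyethyl. Going by the values given here, no measured step tests this change directly. The closest evidence is the modest methyl step (a 2.3-fold higher number from compound 1 to compound 3 (0.35 log units; beyond the scatter)), so no step beyond the scatter is expected, in either direction. The expected step is small (no change at the digits printed from compound 3 to compound 4 (within the scatter)). For compound 4 the estimated value is 16000 nM with an expected range (6000 nM to 40000 nM).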

Compound 4, half-maximal inhibitory concentration: 17000 nM
The estimate for compound 4 lay 1.1-fold (0.03 log units) below the measured number; measured number inside the range.
By their numbers in this assay, from the lowest: compound 1; then compounds 3 and 4 (each within the scatter of the next).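

In this assay, adding a hydroxymethyl on the saturated chain carbon bound to the amide-type nitrogen, which turns methyl into 2-hydroxyethyl, leaves the read-out essentially where it was (a 1.1-fold higher number from compound 3 to compound 4 (0.03 log units; within the scatter)). Set against the unsubstituted amide, the longer group shows a modest rise (a 2.4-fold higher number from compound 1 to compound 4 (0.38 log units; beyond the scatter)), so the added hydroxymethyl does not bring back the lower number of compound 1, and both substituents on the amide nitrogen now point the same way. Nothing in the data shown gives a reason for this.

Going by these compounds, whether an amine or a carboxylic acid at the end of this chain would also leave the number unchanged remains open. So does the effect of a longer chain, such as 3-hydroxypropyl, on the same nitrogen.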